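Replacing Pyridin-3-yl with Thiophen-3-yl on Compound 2

The source may report more compounds than this note shows. Statements on the series, on what has been measured and on what is new or still open speak of the compounds shown alone.

Compound 2 `O=C(NO)c1ccc(/C=C/c2ccnc(-c3cccnc3)c2)cc1` gives 14 nM in an assay on isolated protein for inhibition of protein deacetylase HDAC6 (Homo sapiens), read by fluorescence, with a stated time of 15 min (on this read-out lower numbers stand for stronger inhibition and higher numbers for weaker inhibition), and stands at the lowest number of the three measured compounds. In this assay compound 1 `O=C(NO)c1ccc(/C=C/c2ccnc(-c3cc(F)ccc3O)c2)cc1` gives 130 nM, and compound 3 `O=C(NO)c1ccc(/C=C/c2cccc(-c3cccc(O)c3)c2)cc1` gives 200 nM; both sit higher than compound 2, beyond the scatter. Compound 4 `O=C(NO)c1ccc(/C=C/c2ccnc(-c3ccsc3)c2)cc1` differs from compound 2 by thiophen-3-yl in place of pyridin-3-yl on an aromatic carbon. Among the compounds with values here, the only measured step at this place is a 9.3-fold lower number from compound 1 to compound 2 (0.97 log units; beyond the scatter), which brought in the pyridin-3-yl; no measured step replaces it with thiophen-3-yl, so the size of the change is uncertain, and a step within or only just beyond the scatter toward a higher number is expected. Compound 4 is therefore estimated at 25 nM, with a range from 8 nM to 80 nM. The expected step is a 1.8-fold higher number from compound 2 to compound 4 (0.25 log units; within the scatter).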

Compound 4, half-maximal inhibitory concentration: 54 nM
Beside the measured number, compound 4's estimate is 2.2-fold (0.33 log units) below it; measured number inside the range.
By their numbers in this assay, from the lowest: compound 2; then compound 4; then compounds 1 and 3 (each within the scatter of the next).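

In this assay, thiophen-3-yl gives a weaker result than pyridin-3-yl (a 3.9-fold higher number from compound 2 to compound 4 (0.59 log units; beyond the scatter)), so at this position the choice between these two small aromatic rings matters. Thiophen-3-yl still gives a lower number than 5-fluoro-2-hydroxyphenyl (a 2.4-fold lower number from compound 1 to compound 4 (0.38 log units; beyond the scatter)), which places it between the two earlier groups on this core. No measured evidence here explains these differences. Open, going by these compounds, is how an amine or a carboxylic acid attached to the pyridin-3-yl ring would compare, and whether a furan-3-yl ring would behave like thiophen-3-yl.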